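Hydrogen for methyl on the aromatic nitrogen: cytotoxicity notes

The source may report more compounds than this note shows. Statements on the series, on what has been measured and on what is new or still open speak of the compounds shown alone.

Of the compounds shown here, three have been measured. Compound 1 `CNc1nc(Nc2ccc(C#N)cc2)nc(Oc2ccc(Cl)c3ccccc23)n1` gives 197000 nM in an ADME assay on MT4 cells (Homo sapiens) for cytotoxicity, read by MTT assay, with a stated time of 4 days; on this read-out higher numbers stand for lower toxicity in this test and lower numbers for higher toxicity in this test. Compound 2 `N#Cc1ccc(Nc2nc(N)nc(Oc3ccc(Cl)c4ccccc34)n2)cc1` gives 237000 nM in this assay. Compound 3 `CNc1nc(Nc2ccc(C#N)cc2)nc(Oc2ccc3ccccc3c2Cl)n1` gives 171000 nM in this assay. All three numbers sit close together, and none of the three can be called less or more toxic than another on this basis.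

Compound 1 and compound 2 differ in one place only, (hydrogen in place of methyl on a nitrogen on an aromatic ring). The change made a 1.2-fold higher number from compound 1 to compound 2 (0.08 log units; within the scatter). Compound 3 shares its atoms with compound 1 but joins them differently; the difference between the two cores is not broken down here.

Compound 4 `N#Cc1ccc(Nc2nc(N)nc(Oc3ccc4ccccc4c3Cl)n2)cc1` has not yet been measured in this assay. It stands to compound 3 as compound 2 stands to compound 1: the difference is hydrogen in place of methyl on a nitrogen on an aromatic ring, and the place of the change reads the same in both pairs, so it is the same change. Within the data shown here, the only measured instance of it, a 1.2-fold higher number from compound 1 to compound 2 (0.08 log units; within the scatter), stayed within the scatter, and there is nothing further to go on. The expected step is therefore a 1.2-fold higher number from compound 3 to compound 4 (0.07 log units; within the scatter), resting on a 1.2-fold higher number from compound 1 to compound 2 (0.08 log units; within the scatter) and on the value of compound 3 171000 nM. For compound 4 the estimate in this assay is 200000 nM, with the likely range running from 120000 nM to 340000 nM.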

Compound 4, half-maximal cytotoxic concentration: 32200 nM
Beside the measured number, compound 4's estimate is 6.2-fold (0.79 log units) above it, outside the stated range (below it).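

In this assay the change from methylamino to amino gives a 5.3-fold lower number from compound 3 to compound 4 (0.73 log units; beyond the scatter) and so marks compound 4 as the more toxic of that pair. The change therefore does not carry a single step size from one core to the other in this series: the same change on two cores in this assay, a 1.2-fold higher number (0.08 log units; within the scatter) from compound 1 to compound 2 and a 5.3-fold lower number (0.73 log units; beyond the scatter) from compound 3 to compound 4, 6.4-fold (0.81 log units) apart, beyond the scatter of two such steps

This comparison rests on one pair per core: it shows that the size of the step depended on the core in these two cases, but it does not show what in the two cores sets the gap, nor does it give a rule for any further core of the series.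

Still open, from the compounds shown here alone, is whether the lower number on the core of compound 3 belongs to the amino group alone or would also appear with a larger group on that nitrogen, such as ethylamino or dimethylamino. Equally open, going by these compounds, is whether the core of compound 1 would keep its steps within the scatter with those same groups, or whether a step like the one on the core of compound 3 would appear there too.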